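Swapping the aryl group on the hydrazone carbon

The source may report more compounds than this note shows. Statements on the series, on what has been measured and on what is new or still open speak of the compounds shown alone.

Among the compounds with values here, compound 3 `Cc1ccc(O)c(/C=N\NC(=O)c2oc3cccc(O)c3c2C)c1` is the one member of this small set with a firm number: in a functional assay on PC-3 cells (Homo sapiens) for inhibition (a higher number here means a weaker inhibitor, a lower number a stronger inhibitor), compound 3 gives 7350 nM. Compound 1 `Cc1c(C(=O)N/N=C\c2ccccn2)oc2cccc(O)c12` reaches only a limit of the assay, >= 40000 nM in this assay. Compound 2 `Cc1c(C(=O)N/N=C\c2ccc(O)c(O)c2O)oc2cccc(O)c12` likewise stops at a limit, >= 40000 nM in this assay. Within the data shown here, the single measured step, an at least 5.4-fold lower number from compound 1 to compound 3 (0.73 log units; beyond the scatter), shows that exchanging the group on this carbon can shift potency beyond the scatter, yet compound 1 sits at the limit of >= 40000 nM in this assay, at which 2 of the 3 values shown sit, so the true size of that step is unknown. Compound 4 `Cc1c(C(=O)N/N=C\c2c(O)cccc2F)oc2cccc(O)c12` differs from compound 3 by 2-fluoro-6-hydroxyphenyl in place of 2-hydroxy-5-methylphenyl on a carbon with a double bond to nitrogen. Among the measured compounds shown here, no measured step covers this exact exchange. Compound 4 is therefore expected to land near 15000 nM, between 4000 nM and 40000 nM. The expected step of a 2.0-fold higher number from compound 3 to compound 4 (0.31 log units; beyond the scatter) is modest and may fall within the scatter.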

Compound 4, half-maximal inhibitory concentration: 8050 nM
Beside the measured number, compound 4's estimate is 1.9-fold (0.27 log units) above it; measured number inside the range.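

The step of a 1.1-fold higher number from compound 3 to compound 4 (0.04 log units; within the scatter) shows that, in this assay, 2-fluoro-6-hydroxyphenyl and 2-hydroxy-5-methylphenyl cannot be told apart on this carbon, so the ring can change in more than one place and keep its number. The step of an at least 4.9-fold lower number from compound 1 to compound 4 (0.69 log units; beyond the scatter) confirms that a second hydroxyphenyl group improves on pyridin-2-yl, but its true size stays unknown, since it starts from a limit: the limit of >= 40000 nM in this assay, at which 2 of the 4 values shown sit.

Compound 2, which also carries hydroxyl groups on its ring, stops at the limit of >= 40000 nM, so a hydroxyl alone does not secure this potency. The compounds shown leave open whether a plain phenyl group, or a phenyl ring bearing an amine, would do as well on this carbon.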